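A Fluorine Swap on the Phenyl Ring of a Triazole Amide

The source may hold more compounds than are shown below. What is called first, only, known or untested is meant among the compounds shown, and "the series" means these compounds.

Measured so far:
Compound 1, `Cc1c(C(=O)Nc2ccc(Oc3ccnc4[nH]ccc34)c(F)c2)nnn1-c1ccccc1`: 350 nM
Compound 2, `Cc1c(C(=O)Nc2ccc(Oc3ccnc4[nH]ccc34)c(F)c2)nnn1-c1ccccc1F`: 420 nM

These two compounds were tested in a functional assay on MCF7 cells (Homo sapiens) for cytotoxicity, read by MTT assay, with a stated time of 72 h; a higher number here means a weaker inhibitor, a lower number a stronger inhibitor. Compound 1 gives the lowest of the two numbers, and compound 2 is nearest to it, with the step of a 1.2-fold higher number from compound 1 to compound 2 (0.08 log units; within the scatter). That step puts a fluoro in place of a hydrogen on the phenyl ring attached to the shared core.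

Compound 3, `Cc1c(C(=O)Nc2ccc(Oc3ccnc4[nH]ccc34)c(F)c2)nnn1-c1ccc(F)cc1`, has not been measured. It differs from compound 1 by fluoro in place of hydrogen on an aromatic carbon. Going by the values given here, the only measured step that bears on this is the one from compound 1 to compound 2, which also added fluoro on the same phenyl ring and stayed within the scatter. A similar outcome is expected here: the step of a 1.1-fold higher number from compound 1 to compound 3 (0.06 log units; within the scatter) is estimated to fall within the scatter, with no clear direction. Compound 3 is therefore estimated at 400 nM, with a range from 200 nM to 800 nM.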

Compound 3, half-maximal inhibitory concentration: 170 nM
Estimate against measurement, compound 3: 2.4-fold (0.37 log units) above; the whole stated range lies above it.
By their numbers in this assay, from the lowest: compound 3; then compounds 1 and 2 (each within the scatter of the next).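

Placing the fluoro para to a large group gives the first change in this series that lies beyond the scatter (a 2.1-fold lower number from compound 1 to compound 3 (0.31 log units; beyond the scatter)), whereas the earlier fluoro swap did not. The same atoms on the same ring also give different results when 4-fluorophenyl replaces 2-fluorophenyl (a 2.5-fold lower number from compound 2 to compound 3 (0.39 log units; beyond the scatter)), so in this assay the two fluorophenyl groups are not interchangeable, and compound 3 is the strongest of the three. Nothing shown here explains why the 4-fluorophenyl group gives this result.

From the compounds shown here alone, it remains open whether the gain belongs to fluoro itself or would also appear with another group in the same place, such as chloro, methoxy or an amine. These compounds also leave open whether a second fluoro on the ring of compound 3 would add to the change or take it away.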